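The compounds below may be only part of what the source reports. "The series", "measured", "known", "first", "only" and "open" are said of these compounds alone.

Measured compounds in a functional assay on MIA PaCa-2 cells (Homo sapiens) for inhibition, read by MTT assay, with a stated time of 48 h, tested at 10 uM; on this read-out higher numbers stand for more inhibition of growth at the one concentration tested and lower numbers for less inhibition of growth:
compound 1, `O=C(/C=C/c1ccc(OCc2cn(Cc3ccc(Br)cc3)nn2)cc1)c1ccc(Br)cc1`, gives 29%
compound 2, `O=C(/C=C/c1ccc(OCc2cn(Cc3ccccc3F)nn2)cc1)c1ccc(Br)cc1`, gives 28%
compound 3, `COc1ccc(C(=O)/C=C/c2ccc(OCc3cn(Cc4ccc(Br)cc4)nn3)cc2)cc1`, gives 56%

Compound 3 stands highest of the three on this assay; its step from compound 1 is a number 27 percentage points higher from compound 1 to compound 3 (beyond the scatter), the change being (methoxy in place of bromo on an aromatic carbon). The other change seen is 2-fluorophenyl in place of 4-bromophenyl on a saturated chain carbon bound to an aromatic nitrogen, which gave a number 1 percentage points lower from compound 1 to compound 2 (within the scatter).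

Compound 4, `COc1ccc(C(=O)/C=C/c2ccc(OCc3cn(Cc4ccccc4F)nn3)cc2)cc1`, is not yet measured. It differs from compound 3 by 2-fluorophenyl in place of 4-bromophenyl on a saturated chain carbon bound to an aromatic nitrogen, the same change as from compound 1 to compound 2, here made on the core of compound 3, which differs from the core of compound 1 by methoxy in place of bromo on an aromatic carbon. Because the earlier step of a number 1 percentage points lower from compound 1 to compound 2 (within the scatter) was small, a small step of a number 2 percentage points lower from compound 3 to compound 4 (within the scatter) is expected here as well. Compound 4 is estimated at 54%, expected to fall between 40% and 68%.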

Compound 4, percent growth inhibition at one concentration: 19%
Compound 4: the middle estimate sits 35 percentage points above what was measured, and the stated range ends above it.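

In this assay, 2-fluorophenyl in place of 4-bromophenyl gives a number 37 percentage points lower from compound 3 to compound 4 (beyond the scatter), so this step does not carry over unchanged from the core of compound 1 to the core of compound 3: the same change on two cores in this assay, a number 1 percentage points lower (within the scatter) from compound 1 to compound 2 and a number 37 percentage points lower (beyond the scatter) from compound 3 to compound 4, 36 percentage points apart, beyond the scatter of two such steps. With the 2-fluorobenzyl group in place, methoxy in place of bromo gives a number 9 percentage points lower from compound 2 to compound 4 (within the scatter), so that change also differs with its partner group: the same change on two cores in this assay, a number 27 percentage points higher (beyond the scatter) from compound 1 to compound 3 and a number 9 percentage points lower (within the scatter) from compound 2 to compound 4, 36 percentage points apart, beyond the scatter of two such steps. The two changes therefore do not add up across these four compounds, but the data do not show why, nor whether this holds beyond one concentration and one cell line.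

As far as these compounds go, it remains open whether the drop on the core of compound 3 goes with the fluorine or with the loss of the bromine. From the compounds shown here alone, how a plain benzyl, an amine or a carboxylic acid in the same place would read on either core also stays open.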